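Swapping a nitro for a nitrile on a shared core

The source may hold more compounds than are shown below. What is called first, only, known or untested is meant among the compounds shown, and "the series" means these compounds.

Measured so far, in an assay on membranes from brain for displacement of a labelled ligand from Sigma non-opioid intracellular receptor 1 (Cavia porcellus), read by scintillation counting, with a stated time of 120 min; on this read-out lower numbers stand for stronger inhibition and higher numbers for weaker inhibition:
- compound 1 `Cc1ccc(-c2scc3c2CCOC32CCN(Cc3ccccc3)CC2)cc1`: 3.6 nM
- compound 2 `COc1ccc(-c2scc3c2CCOC32CCN(Cc3ccccc3)CC2)cc1`: 1.5 nM
- compound 3 `O=[N+]([O-])c1ccc(-c2scc3c2CCOC32CCN(Cc3ccccc3)CC2)cc1`: 1.7 nM

All three share one core and differ only in the group carried on the outer six-membered aromatic ring. Compound 3 gives the second highest of the three numbers; its nearest neighbour is compound 2, and the gap between them is within the scatter, while the gap to compound 1 is beyond it.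

Compound 4 `N#Cc1ccc(-c2scc3c2CCOC32CCN(Cc3ccccc3)CC2)cc1` is not yet measured. It differs from compound 3 by a single change: cyano in place of nitro on an aromatic carbon.

Among the compounds with values here, two measured steps bear on this change. The replacement a 1.1-fold higher number from compound 2 to compound 3 (0.05 log units; within the scatter) shows that two different groups at this position can give numbers that are not told apart. The replacement a 2.1-fold lower number from compound 1 to compound 3 (0.33 log units; beyond the scatter) shows that a change here can still move the number, though only modestly. Within the data shown here, nothing measured so far separates nitro from cyano, so no step beyond the scatter is expected in this assay; the estimated step is a 1.2-fold higher number from compound 3 to compound 4 (0.07 log units; within the scatter).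

Compound 4 is therefore expected to give about 2 nM, within a range from 0.7 nM to 6 nM.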

Compound 4, inhibition constant: 3.4 nM
Compound 4: middle estimate off by 1.7-fold (0.23 log units), on the low side; the range from low to high includes it.
By their numbers in this assay, from the lowest: compounds 2, 3, 4 and 1 (each within the scatter of the next, the first and the last beyond it).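

In this assay, putting cyano in place of nitro on this aromatic carbon gives a 2.0-fold higher number from compound 3 to compound 4 (0.30 log units; within the scatter), so the two groups are not told apart here, even though a triple bond enters where a double bond leaves. Cyano also cannot be told apart from methyl, with a 1.1-fold lower number from compound 1 to compound 4 (0.02 log units; within the scatter), but it can be separated from methoxy, with a 2.3-fold higher number from compound 2 to compound 4 (0.36 log units; beyond the scatter), a modest step beyond the scatter. Across these four groups, the largest steps at this position remain modest, and nothing shown here accounts for the small differences among them.

On these data alone, it remains open whether this position would stay so tolerant of change with a different kind of group, such as an amine, a carboxylic acid or a longer chain. As far as these compounds go, it is also open whether methyl, methoxy, nitro and cyano would give similarly close numbers at another place on the outer six-membered aromatic ring, or in a test on a different receptor.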